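The source may hold more compounds than are shown below. What is called first, only, known or untested is meant among the compounds shown, and "the series" means these compounds.

Compound 2 `C/C(=N\OCC(=O)O)c1ccc(N(C)C)cc1` is the starting point of this step, and it was tested in a functional assay on the whole organism for inhibition, with Rattus norvegicus as the target, read by paw edema, with stated times of 1 h and 3 h, at a dose of 50 mg/kg by the oral route; a higher number here means more inhibition at the dose given (going by the name of the read-out), a lower number less inhibition. In this assay compound 2 gives < 20%, and that value is a limit of the assay rather than a number. Compound 1 `C/C(=N\OCC(=O)O)c1ccc(C#N)cc1` shares the same core but carries cyano where compound 2 carries dimethylamino. In this assay compound 1 gives < 20%, which is likewise a limit. Among the measured compounds shown here, the single measured step, a step that the two limits leave unreadable from compound 1 to compound 2, therefore cannot be given a size, because of the limit of < 20% in this assay, at which 2 of the 2 values shown sit. Compound 3 `C/C(=N\OCC(=O)O)c1ccc([N+](=O)[O-])cc1` is the compound not yet measured, and it differs from compound 2 in one place: nitro in place of dimethylamino on an aromatic carbon. For the measured compounds named here, no measured step of readable size bears on this change; the only step in hand rests on a limit at both ends and so gives neither a direction nor a magnitude. Compound 3 is accordingly expected to stand near compound 2, with the step that the limit leaves unreadable from compound 2 to compound 3 estimated as nothing beyond the scatter. For compound 3 in this assay the estimate is 15%, with a range from 0% to 35%.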

Compound 3, a percentage reported as inhibition, in the whole organism at one dose (the size of the read-out at that dose, not a potency): < 20%
Compound 3 ended at the assay's limit; the forecaster's own chance of this, stated with the estimate: 65%; the middle value does not contradict the limit.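

No new step can be read between compound 3 and compound 2 or compound 1 in this assay because all three values are limits of the assay and not numbers: the limit of < 20% in this assay, at which 3 of the 3 values shown sit. The compounds shown leave open how the cyano, dimethylamino and nitro groups truly compare, and whether any group at this place gives inhibition clear of that limit.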